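Swapping chloro for trifluoromethyl in compound 2

The source may report more compounds than this note shows. Statements on the series, on what has been measured and on what is new or still open speak of the compounds shown alone.

Measured in a functional assay on A549 cells (Homo sapiens) for antiproliferative activity, read by MTT assay, with a stated time of 72 h; a lower number here means a stronger inhibitor, a higher number a weaker inhibitor:
Compound 1 `CCn1cc(C(=O)O)c(=O)c2cc(F)c(N3CCN(C(=N)NS(=O)(=O)c4ccc(C(F)(F)F)cc4)CC3)cc21`: 71 nM
Compound 2 `CCn1cc(C(=O)O)c(=O)c2cc(F)c(N3CCN(C(=N)NS(=O)(=O)c4ccccc4Cl)CC3)cc21`: 71 nM
Compound 3 `N=C(NS(=O)(=O)c1ccccc1Cl)N1CCN(c2cc3c(cc2F)c(=O)c(C(=O)O)cn3C2CC2)CC1`: 71 nM

Level with compound 1 and compound 3, compound 2 sits at 71 nM. Compound 4 `CCn1cc(C(=O)O)c(=O)c2cc(F)c(N3CCN(C(=N)NS(=O)(=O)c4ccccc4C(F)(F)F)CC3)cc21` differs from it in one place, with trifluoromethyl in place of chloro on an aromatic carbon, ortho to a large group: trifluoromethyl in place of chloro on an aromatic carbon. This exact swap has not been measured, so the expectation rests on two neighbouring steps. The more relevant one changes the same aryl group on the sulfonyl sulfur, from 4-(trifluoromethyl)phenyl to 2-chlorophenyl, and gives no change at the digits printed from compound 1 to compound 2 (within the scatter). The other, cyclopropyl in place of ethyl on an aromatic nitrogen, gives no change at the digits printed from compound 2 to compound 3 (within the scatter). Neither step moved the value, though three compounds are a thin basis for a trend. No shift beyond the scatter is therefore expected in this assay, in either direction, and the expected step is no change at the digits printed from compound 2 to compound 4 (within the scatter). For compound 4 the estimated value is 71 nM, with an expected range of 30 nM to 170 nM.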

Compound 4, half-maximal inhibitory concentration: 71 nM
Compound 4: middle estimate and measured number agree at the digits printed; the measured number falls inside the stated range.
By their numbers in this assay, from the lowest: compounds 1, 2, 3 and 4 (each within the scatter of the next).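

In this assay, the aromatic carbon that carries chloro in compound 2 also accepts trifluoromethyl, a group of 4 heavy atoms in place of 1, and the swap gives no change at the digits printed from compound 2 to compound 4 (within the scatter). The earlier step from compound 1 to compound 2 changed both the substituent and its place on the ring, whereas 2-(trifluoromethyl)phenyl in place of 4-(trifluoromethyl)phenyl changes the place alone and gives no change at the digits printed from compound 1 to compound 4 (within the scatter). No measurement shown offers an explanation for this flat result.

With all four compounds level, the data cannot show how much this aryl group contributes to the activity. Going by these compounds, whether an amine or a carboxylic acid on this aromatic carbon, or a plain phenyl on the sulfonyl sulfur, would keep the same value remains open.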